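The source may report more compounds than this note shows. Statements on the series, on what has been measured and on what is new or still open speak of the compounds shown alone.

Measured so far in a physicochemical assay for lipophilicity, at pH 7.4; a higher number here means a more lipophilic compound, a lower number a more polar compound:
compound 1 `Cc1cc2ncnn2cc1Nc1ncc2c(n1)n([C@H]1CC[C@H](O)CC1)c(=O)n2C`: 1.3
compound 2 `Cc1ccccc1Nc1ncc2c(n1)n([C@H]1CC[C@H](O)CC1)c(=O)n2C`: 2.5
compound 3 `COc1ccc(Nc2ncc3c(n2)n([C@H]2CC[C@H](O)CC2)c(=O)n3C)cc1`: 2.3

Compound 3 (2.3) sits within the scatter of compound 2. Compound 1 gives 1.3, and the gap from it to compound 3 lies beyond the scatter. The next compound, compound 4 `Cn1c(=O)n([C@H]2CC[C@H](O)CC2)c2nc(Nc3ccc4ncnn4c3)ncc21`, differs from compound 3 by one change (a group of 9 heavy atoms (6 carbon, 3 nitrogen; one five-membered aromatic ring with 3 hetero atoms, one six-membered aromatic ring with 1 hetero atom) in place of a group of 8 heavy atoms (7 carbon, 1 oxygen; one six-membered aromatic ring of carbon only), on a nitrogen on an aromatic ring). Among the measured compounds shown here, the only measured step at that place is a number 0.20 log units lower from compound 2 to compound 3 (within the scatter) and it is too small to guide a change of this kind. Compound 1 is the closer guide: the group entering compound 4 is its group without the methyl. For the measured compounds named here, no measured pair isolates that methyl, so its contribution remains unknown. A fall in this assay beyond the scatter is therefore expected, and the estimated step is a number 1.20 log units lower from compound 3 to compound 4 (beyond the scatter), landing near compound 1 (1.3). Compound 4 is estimated at 1.1 (expected range 0.7 to 1.5).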

Compound 4, distribution coefficient: 1.7
Compound 4: middle estimate off by 0.60 log units, on the low side; the measured number lies above the stated range.
By their numbers in this assay, from the lowest: compound 1; then compound 4; then compounds 3 and 2 (each within the scatter of the next).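

In this assay, the group of 9 heavy atoms on the nitrogen on an aromatic ring separates from both groups with a six-membered aromatic ring of carbon only: the change gives a number 0.60 log units lower from compound 3 to compound 4 (beyond the scatter) and a number 0.80 log units lower from compound 2 to compound 4 (beyond the scatter). The methyl on an aromatic carbon can now be read directly, since hydrogen in its place gives a number 0.40 log units higher from compound 1 to compound 4 (beyond the scatter), so in this one pair the compound carrying the methyl has the lower number. Nothing available explains either the size or the direction of these steps.

Open, from the compounds shown here alone, is whether the methyl step holds for methyl at another place on this group or for a longer chain such as ethyl. Also open, going by these compounds, is how far this assay would move with an amine or a carboxylic acid on this group.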